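Removing the ring methyl next to the acetal oxygen

The source may report more compounds than this note shows. Statements on the series, on what has been measured and on what is new or still open speak of the compounds shown alone.

For the measured compounds named here, compound 2, `CO[C@]1(C)C[C@H](O)C[C@@H](CSc2nc(-c3ccccc3)c(-c3ccccc3)[nH]2)O1`, holds the lowest number of the two measured so far. In an assay on microsomes from liver for inhibition of sterol O-acyltransferase 1 (Rattus norvegicus) (on this read-out higher numbers stand for weaker inhibition and lower numbers for stronger inhibition), compound 2 gives 30 nM, while compound 1, `C[C@@]1(O)CC(=O)OC(CSc2nc(-c3ccccc3)c(-c3ccccc3)[nH]2)C1`, gives 170 nM in this assay; the gap between the two lies beyond the scatter. Going by the values given here, no pair of measured compounds differs in a single place, so the next step rests on the structural change alone. Compound 3, `CO[C@H]1C[C@H](O)C[C@@H](CSc2nc(-c3ccccc3)c(-c3ccccc3)[nH]2)O1`, differs from compound 2 by hydrogen in place of methyl on a saturated ring carbon; the shared core and the hydroxy group are unchanged. Among the compounds with values here, a single methyl at a saturated ring carbon has no precedent in the measured pair, so a step not beyond the scatter, or a modest loss, is expected. The step from compound 2 to compound 3 is estimated as a 1.5-fold higher number from compound 2 to compound 3 (0.18 log units; within the scatter). Compound 3 is expected to give 45 nM in this assay, with a range from 15 nM to 150 nM.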

Compound 3, half-maximal inhibitory concentration: 90 nM
Beside the measured number, compound 3's estimate is 2.0-fold (0.30 log units) below it, within the range that was stated.
By their numbers in this assay, from the lowest: compound 2; then compounds 3 and 1 (each within the scatter of the next).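

In this assay, the methyl on the saturated ring carbon next to the ring oxygen now has a step of its own: hydrogen in its place gives a 3.0-fold higher number from compound 2 to compound 3 (0.48 log units; beyond the scatter), so this position responds to the change, though only modestly. Replacing the whole group on the saturated chain carbon bound to a sulfur gives a 1.9-fold lower number from compound 1 to compound 3 (0.28 log units; within the scatter), so without the methyl, the ring of compound 3 cannot be told apart from that of compound 1 on this read-out. No measurement at hand bears on the origin of the methyl step.

From the compounds shown here alone, whether ethyl or a longer chain at this ring carbon would give a lower or higher number than methyl remains open. So does the effect of an amine in place of the hydroxy group.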